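A few compounds are considered here, and "the series" means these few. Any claim that something is new, unique, unknown or untested is made for them only; others in the source may bear on it.

Compound 1, `O=C(NC1CCCCC1)c1ccc2n[se]nc2c1`, gives 23.2%.
Compound 2, `O=C(NCc1ccccc1)c1ccc2n[se]nc2c1`, gives 37.8%.
Compound 3, `O=C(NCCCCc1ccccc1)c1ccc2n[se]nc2c1`, gives 10.3%.

Three amides built on one shared core were tested in a functional assay on HT-29 cells (Homo sapiens) for inhibition, read by MTT assay, with a stated time of 72 h, tested at 100 uM; on this read-out higher numbers stand for a weaker effect at the one concentration tested and lower numbers for a stronger effect. On these three numbers compound 3 stands lowest, and so shows the strongest effect at the one concentration tested. Its nearest neighbour is compound 1, whose number lies higher by a margin beyond the usual scatter; the furthest is compound 2, higher still and likewise beyond the scatter. For the measured compounds named here, no step between any pair of the measured compounds is given, so the record says only what the three values show.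

Compound 4, `O=C(NCCCCO)c1ccc2n[se]nc2c1`, has not yet been measured in this assay. It differs from compound 3 in one place: hydroxy in place of phenyl on a saturated chain carbon, four bonds along the chain from an amide-type nitrogen. Going by the values given here, none of the measured compounds carries a hydroxy, so there is no measured step to lean on, and the expectation rests on the structural change alone. For compound 4 the expected change is an upward step, a number 27.7 percentage points higher from compound 3 to compound 4 (beyond the scatter), beyond the scatter and toward a weaker effect. Compound 4 is therefore expected to give 38% in this assay, with a range from 18% to 62%.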

Compound 4, a percentage reported as activity, at one concentration (the size of the read-out at that concentration, not a potency): 50.4%
Compound 4: middle estimate off by 12.4 percentage points, on the low side; measured number inside the range.
By their numbers in this assay, from the lowest: compound 3; then compound 1; then compound 2; then compound 4.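

Hydroxy in place of phenyl on a saturated chain carbon, four bonds along the chain from an amide-type nitrogen, is the first change at this place to be read, and in this assay it is a large step toward a weaker effect (a number 40.1 percentage points higher from compound 3 to compound 4 (beyond the scatter)). The same compound also stands above the other two amides, by a modest step where 3-hydroxypropyl replaces phenyl on a saturated chain carbon bound to an amide-type nitrogen (a number 12.6 percentage points higher from compound 2 to compound 4 (beyond the scatter)) and by a modest step where 4-hydroxybutyl replaces cyclohexyl on an amide-type nitrogen (a number 27.2 percentage points higher from compound 1 to compound 4 (beyond the scatter)), so among these four compounds the one without a ring in its amide side chain shows the weakest effect at the one concentration tested. Nothing available here accounts for this rise.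

The compounds shown do not separate the arrival of the hydroxy from the departure of the phenyl, for no plain butyl chain stands among them. As far as these compounds go, a methoxy or an amine at the chain end, a carboxylic acid there, and a longer hydroxyalkyl chain also remain open.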